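A few compounds are considered here, and "the series" means these few. Any claim that something is new, unique, unknown or untested is made for them only; others in the source may bear on it.

Working notes on the series. In a functional assay on A549 cells (Homo sapiens) for inhibition, read by sulforhodamine B assay, with a stated time of 48 h (on this read-out higher numbers stand for weaker inhibition of growth and lower numbers for stronger inhibition of growth), compound 1 (`COc1cc(C=C(C(=O)/C=C/c2ccc(OC)c(OC)c2)C(=O)/C=C/c2ccc(OC)c(OC)c2)ccc1O`) gives 530 nM, compound 2 (`COc1ccc(OC)c(C=C(C(=O)/C=C/c2ccc(O)c(OC)c2)C(=O)/C=C/c2ccc(O)c(OC)c2)c1`) gives 670 nM and compound 3 (`COc1cc(/C=C/C(=O)C(=Cc2ccc(OC)c(OC)c2)C(=O)/C=C/c2ccc(O)c(OC)c2)ccc1O`) gives 430 nM. Compound 3 lies within the scatter of both other compounds, so it holds no separate rank on these numbers. Compound 4 (`COc1ccc(C=C(C(=O)/C=C/c2ccc(O)c(OC)c2)C(=O)/C=C/c2ccc(O)c(OC)c2)c(OC)c1`) has not been measured. Its change from compound 3 is 2,4-dimethoxyphenyl in place of 3,4-dimethoxyphenyl on a double-bonded chain carbon bound to a double-bonded chain carbon, with 2,4-dimethoxyphenyl in place of 3,4-dimethoxyphenyl on a double-bonded chain carbon bound to a double-bonded chain carbon. For the measured compounds named here, one measured step bears on this place: a 1.6-fold lower number from compound 2 to compound 3 (0.19 log units; within the scatter), where 3,4-dimethoxyphenyl replaces 2,5-dimethoxyphenyl. Going by the values given here, a single step is thin evidence, and no compound carrying 2,4-dimethoxyphenyl has a value yet. No shift beyond the scatter is therefore expected in this assay, in either direction. The estimated step is a 1.2-fold higher number from compound 3 to compound 4 (0.09 log units; within the scatter), which is expected to stay within the scatter. For compound 4 the estimated value is 530 nM, with an expected range of 270 nM to 1050 nM.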

Compound 4, concentration for 50% growth inhibition: 690 nM
The estimate for compound 4 lay 1.3-fold (0.11 log units) below the measured number, and the stated range covers the measured number.
By their numbers in this assay, from the lowest: compounds 3, 1, 2 and 4 (each within the scatter of the next).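

With compound 4, 2,4-dimethoxyphenyl has its first value on a double-bonded chain carbon bound to a double-bonded chain carbon, and in this assay its exchange for 3,4-dimethoxyphenyl stays within the scatter (a 1.6-fold higher number from compound 3 to compound 4 (0.21 log units; within the scatter)). The exchange for 2,5-dimethoxyphenyl also stays within the scatter (a 1.0-fold higher number from compound 2 to compound 4 (0.01 log units; within the scatter)), so these numbers do not separate the 2,4-dimethoxyphenyl, 3,4-dimethoxyphenyl and 2,5-dimethoxyphenyl groups at this place. No measurement offers an explanation for this result.

The compounds shown leave open whether this place tolerates only dimethoxyphenyl groups or would respond to a group of another kind, such as a phenyl ring carrying an amine or a carboxylic acid. They also leave open whether a single methoxy group on the phenyl ring would give a step beyond the scatter.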